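Replacing 4-methoxyphenyl with thiophen-2-yl

This account rests on a few compounds, and the source may have more. Where it says the series, first, only, none or still open, it means among the compounds named here.

In a functional assay on DU-145 cells (Homo sapiens) for inhibition, read by MTT assay, with a stated time of 48 h (on this read-out higher numbers stand for weaker inhibition and lower numbers for stronger inhibition), compound 1 `CS(=O)(=O)c1ccc(-c2nc3ccccn3c2Sc2ccccc2)cc1` gives 67800 nM and compound 2 `COc1ccc(-c2nc3ccccn3c2Sc2ccccc2)cc1` gives 76800 nM, so the two stand level within the scatter. Compound 3 `c1ccc(Sc2c(-c3cccs3)nc3ccccn23)cc1` departs from compound 2 by one change: thiophen-2-yl in place of 4-methoxyphenyl on an aromatic carbon. For the measured compounds named here, the only measured step is a 1.1-fold higher number from compound 1 to compound 2 (0.05 log units; within the scatter), and it put methoxy in place of methylsulfonyl, so it offers only thin guidance for swapping a whole group. The expected step in this assay is a 1.3-fold lower number from compound 2 to compound 3 (0.11 log units; within the scatter), with none expected beyond the scatter. For compound 3 the estimated value is 60000 nM, with an expected range from 25000 nM to 130000 nM.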

Compound 3, half-maximal inhibitory concentration: 24100 nM
Estimate against measurement, compound 3: 2.5-fold (0.40 log units) above, and the stated range ends above it.
By their numbers in this assay, from the lowest: compound 3; then compounds 1 and 2 (each within the scatter of the next).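

In this assay, the ring at this position matters: thiophen-2-yl in place of 4-methoxyphenyl gives a 3.2-fold lower number from compound 2 to compound 3 (0.50 log units; beyond the scatter). The earlier step, methoxy in place of methylsulfonyl, stayed within the scatter, so exchanging the whole ring moved the number where changing a group on that ring did not. No measurement available here explains the drop. The compounds shown leave open whether furan-2-yl or a pyridine ring would behave like thiophen-2-yl. They also leave open whether an amine on the thiophene would lower the number further.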